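The compounds below may be only part of what the source reports. "The series", "measured", "known", "first", "only" and "open" are said of these compounds alone.

Compound 1, `COc1ccccc1/C=C1\CCc2cc(OC)c(OC)cc2C1=O`, is the starting point of this short series. In a functional assay on Jurkat cells (Homo sapiens) for antiproliferative activity, read by MTT assay (on this read-out lower numbers stand for stronger inhibition and higher numbers for weaker inhibition), compound 1 gives only a limit, > 50000 nM, not a number. Compound 2, `COc1cc2c(cc1OC)C(=O)/C(=C/c1ccc(O)cc1)CC2`, carries a 4-hydroxyphenyl group in place of the 2-methoxyphenyl group of compound 1; in this assay compound 2 gives 19000 nM. That change brought an at least 2.6-fold lower number from compound 1 to compound 2 (0.42 log units; beyond the scatter). Among the measured compounds shown here, compound 2 therefore holds the only real number in this assay, while the other value is a limit, as the limit of > 50000 nM in this assay, at which 1 of the 2 values shown sits, records.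

Compound 3, `COc1cc2c(cc1OC)C(=O)/C(=C/c1ccc(N)cc1)CC2`, differs from compound 2 by amino in place of hydroxy on an aromatic carbon. For the measured compounds named here, only one measured step exists, the one from compound 1 to compound 2, and it swapped one whole aryl substituent for another; it does not directly test an exchange of hydroxy for amino on the same aromatic carbon. The expectation for compound 3 therefore rests on the groups being alike in size and in donor and acceptor count, so a step of a 2.1-fold lower number from compound 2 to compound 3 (0.32 log units; beyond the scatter) is estimated, pointing toward a lower number. Compound 3 is expected to give about 9000 nM, likely between 2500 nM and 35000 nM.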

Compound 3, half-maximal inhibitory concentration: 40000 nM
For compound 3 the middle estimate is 4.4-fold (0.65 log units) below the measured one; measured number above the stated range.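

Among the compounds shown here, this is the first single-group exchange: with the rest of compound 2 unchanged, amino in place of hydroxy on the aromatic carbon gives a 2.1-fold higher number from compound 2 to compound 3 (0.32 log units; beyond the scatter) in this assay. The two groups match in heavy-atom count and in hydrogen-bond donors and acceptors, yet they are not interchangeable at this place, and here hydroxy gives the lower number by a modest margin. Compound 3 also cannot be clearly separated from compound 1, with an at least 1.2-fold lower number from compound 1 to compound 3 (0.09 log units; that floor lies within the scatter), and that floor rests on a value that is a limit and not a number: the limit of > 50000 nM in this assay, at which 1 of the 3 values shown sits.

The compounds shown leave open whether another group on this aromatic carbon, such as a fluorine atom, an acetamide or a carboxylic acid, would give a lower number than compound 2. From the compounds shown here alone, the step from compound 1 to compound 2 exchanged a whole aryl group, so it also stays open how a methoxy on the same aromatic carbon would compare with the hydroxy of compound 2.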